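Swapping methyl for fluoro on the sulfur-bearing ring

The compounds below may be only part of what the source reports. "The series", "measured", "known", "first", "only" and "open" are said of these compounds alone.

Measured compounds:
- compound 1, `Nc1ccccc1NC(=O)/C=C/c1ccc(CSc2ccc(Cl)cc2)cc1`: 59.6%
- compound 2, `Cc1cc(C)cc(SCc2ccc(/C=C/C(=O)Nc3ccccc3N)cc2)c1`: 47.3%
- compound 3, `Cc1ccc(SCc2ccc(C(=O)Nc3ccccc3N)cc2)cc1`: 78.3%

These three compounds were tested in a functional assay on A549 cells (Homo sapiens) for inhibition, read by CCK-8 assay, with a stated time of 72 h, tested at 8 uM; a higher number here means more inhibition of growth at the concentration tested, a lower number less inhibition of growth. Compound 3 shows the highest of the three numbers; compound 1 lies closer to it, and compound 2 is furthest away, both gaps being beyond the usual scatter.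

The next compound, compound 4, has the structure `Nc1ccccc1NC(=O)c1ccc(CSc2ccc(F)cc2)cc1`. It differs from compound 3 in one place: fluoro in place of methyl on an aromatic carbon. Put another way, the (4-methylphenyl)sulfanyl group becomes a (4-fluorophenyl)sulfanyl group.

For the measured compounds named here, only one measured step touches the same ring. Between compound 1 and compound 2 the group on the sulfur changed from 4-chlorophenyl to 3,5-dimethylphenyl, and this gave a number 12.3 percentage points lower from compound 1 to compound 2 (beyond the scatter). That step sits on a different core and exchanges a halogen for methyl groups, so it offers only a loose guide; it hints that a halogen on this ring is at least not worse than methyl.

For compound 4 the expected step is therefore small, a number 2.3 percentage points lower from compound 3 to compound 4 (within the scatter), most likely within the scatter. The estimated value for compound 4 in this assay is 76%, with a likely range from 60% to 90%.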

Compound 4, percent growth inhibition at one concentration: 44.5%
Beside the measured number, compound 4's estimate is 31.5 percentage points above it, and the stated range ends above it.
By their numbers in this assay, from the lowest: compounds 4 and 2 (each within the scatter of the next); then compound 1; then compound 3.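

In this assay, exchanging methyl for fluoro on an aromatic carbon para to a large group gives a number 33.8 percentage points lower from compound 3 to compound 4 (beyond the scatter), so this one atom matters a great deal on the core shared by these two compounds. For the compounds shown here, the only earlier change on this ring gave a number 12.3 percentage points lower from compound 1 to compound 2 (beyond the scatter), but that step lay on a different core and replaced a 4-chlorophenyl group with a 3,5-dimethylphenyl group, so it could not isolate methyl from halogen at this carbon; here, with all else held fixed, the methyl compound gives the higher number, the opposite direction to the halogen-favouring step on the other core. Nothing measured here explains why such a small exchange has so large an effect.

On these data alone, it remains open whether a methoxy group, an amine or a longer chain such as ethyl on this carbon would give a number closer to that of the methyl compound or to that of the fluoro compound. Also open, as far as these compounds go, is whether the exchange of methyl for fluoro would have a similar effect on the core of compound 1, since that core carries neither of these two groups here.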